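Replacing the cyclopropyl on the urea of compound 3

A few compounds are considered here, and "the series" means these few. Any claim that something is new, unique, unknown or untested is made for them only; others in the source may bear on it.

Compound 3 `COc1ncc(-c2ccc3nc(NC(=O)NC4CC4)sc3c2)cc1NS(=O)(=O)c1ccc(F)cc1` carries a cyclopropylcarbamoyl group on the shared core. Going by the values given here, in a functional assay on MCF7 cells (Homo sapiens) for antiproliferative activity, read by MTT assay, with a stated time of 72 h (on this read-out lower numbers stand for stronger inhibition and higher numbers for weaker inhibition), compound 3 gives 1190 nM, the highest of the three numbers so far. Compound 1 `COc1ncc(-c2ccc3nc(NC(=O)NCCN(C)C)sc3c2)cc1NS(=O)(=O)c1ccc(F)cc1` gives 500 nM and compound 2 `COc1ncc(-c2ccc3nc(NC4CC4)sc3c2)cc1NS(=O)(=O)c1ccc(F)cc1` gives 450 nM; the steps of a 2.4-fold higher number from compound 1 to compound 3 (0.38 log units; beyond the scatter) and a 2.6-fold higher number from compound 2 to compound 3 (0.42 log units; beyond the scatter) both run toward weaker inhibition, while a 1.1-fold lower number from compound 1 to compound 2 (0.05 log units; within the scatter) stays within the scatter.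

Compound 4 `COc1ncc(-c2ccc3nc(NC(=O)NCCN4CCCCC4)sc3c2)cc1NS(=O)(=O)c1ccc(F)cc1` differs from compound 3 in one place: 2-(piperidin-1-yl)ethyl in place of cyclopropyl on an amide-type nitrogen. The step that bears most on this change is a 2.4-fold higher number from compound 1 to compound 3 (0.38 log units; beyond the scatter), where cyclopropyl replaced 2-(dimethylamino)ethyl on the same amide-type nitrogen and the number rose modestly. Compound 4 brings a two-carbon chain ending in a ring nitrogen back to that position, so a modest step back toward the number of compound 1 is expected in this assay, a 2.2-fold lower number from compound 3 to compound 4 (0.34 log units; beyond the scatter). Compound 4 is therefore estimated at 550 nM, with a range from 250 nM to 1300 nM.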

Compound 4, half-maximal inhibitory concentration: 450 nM
Compound 4: the middle estimate sits 1.2-fold (0.09 log units) above what was measured; the range from low to high includes it.
By their numbers in this assay, from the lowest: compounds 2, 4 and 1 (each within the scatter of the next); then compound 3.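

In this assay, the return of a chain ending in an amine to the amide-type nitrogen undoes the loss seen with cyclopropyl, a 2.6-fold lower number from compound 3 to compound 4 (0.42 log units; beyond the scatter), and a 1.1-fold lower number from compound 1 to compound 4 (0.05 log units; within the scatter) shows that piperidin-1-yl and dimethylamino at the chain end cannot be told apart here. With no change at the digits printed from compound 2 to compound 4 (within the scatter), the (2-(piperidin-1-yl)ethyl)carbamoyl group also stands level with the cyclopropyl on the nitrogen on the aromatic ring, so among these four compounds only the cyclopropylcarbamoyl group of compound 3 stands apart. Nothing measured here accounts for this result.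

From the compounds shown here alone, it remains open whether the chain's terminal nitrogen or the chain alone carries the step from compound 3 to compound 4. A plain butyl group, a morpholine at the chain end or a longer chain ending in the same amine could separate these readings.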